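Replacing Carboxy by Phenyl: Expected Cytotoxicity of Compound 4

A few compounds are considered here, and "the series" means these few. Any claim that something is new, unique, unknown or untested is made for them only; others in the source may bear on it.

Three compounds have been measured in a functional assay on PC-12 cells (Rattus norvegicus) for cytotoxicity, read by MTT assay, with stated times of 3 h and 2 h, tested at 0.1 uM; a higher number here means a stronger effect of the compound at the concentration tested, a lower number a weaker effect:

Compound 1 `O=C(CCCCC1CCSS1)NCc1cn(CCCOc2ccc3ccc(=O)oc3c2)nn1` gives 37.8%.
Compound 2 `CCOC(=O)c1cc2ccc(OCCCn3cc(CNC(=O)CCCCC4CCSS4)nn3)cc2oc1=O` gives 28%.
Compound 3 `O=C(CCCCC1CCSS1)NCc1cn(CCCOc2ccc3cc(C(=O)O)c(=O)oc3c2)nn1` gives 43.4%.

Compound 3 has the highest of the three numbers, but compound 1 lies within the scatter of it: a number 5.6 percentage points higher from compound 1 to compound 3 (within the scatter). The gap to compound 2 is larger: a number 15.4 percentage points higher from compound 2 to compound 3 (beyond the scatter). Compound 4 `O=C(CCCCC1CCSS1)NCc1cn(CCCOc2ccc3cc(-c4ccccc4)c(=O)oc3c2)nn1` differs from compound 3 in one place: phenyl in place of carboxy on an aromatic carbon. For the measured compounds named here, two measured steps bear on this change. The carboxy group made little difference when it replaced hydrogen, as a number 5.6 percentage points higher from compound 1 to compound 3 (within the scatter) shows, and the related ethoxycarbonyl group likewise stayed within the scatter, as a number 9.8 percentage points lower from compound 1 to compound 2 (within the scatter) shows. Removing the carboxy should therefore matter little, and nothing in the measured set says how a phenyl group behaves there. For compound 4 the expected step is a number 7.4 percentage points lower from compound 3 to compound 4 (within the scatter), no further than the scatter, because a number 5.6 percentage points higher from compound 1 to compound 3 (within the scatter) was itself small. The estimated value for compound 4 in this assay is 36%, with a range from 22% to 50%.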

Compound 4, a percentage reported as activity, at one concentration (the size of the read-out at that concentration, not a potency): 33.9%
For compound 4 the middle estimate is 2.1 percentage points above the measured one; the measured number falls inside the stated range.
By their numbers in this assay, from the lowest: compounds 2, 4, 1 and 3 (each within the scatter of the next, the first and the last beyond it).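

In this assay, putting phenyl in place of carboxy on this aromatic carbon, two atoms from the ring oxygen, gives a number 9.5 percentage points lower from compound 3 to compound 4 (within the scatter). The place therefore accepts a six-membered aromatic ring of carbon only, with 0 hydrogen-bond donors and 0 hydrogen-bond acceptors, without a step beyond the scatter, and the same holds against the ester and the bare position: a number 5.9 percentage points higher from compound 2 to compound 4 (within the scatter) and a number 3.9 percentage points lower from compound 1 to compound 4 (within the scatter). Phenyl thus joins carboxy and ethoxycarbonyl as a third group whose step from hydrogen stays within the scatter, and compound 4 does not separate from compound 1, compound 2 or compound 3, although compound 2 and compound 3 do stand apart from each other.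

Nothing shown here explains why these steps are so small. Still open, from the compounds shown here alone, is whether an amine, a pyridine ring or a phenyl ring bearing a chlorine atom at this place would also stay within the scatter, and whether compound 4 would read the same at other concentrations.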